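Expected Effect of an Added Methyl on Compound 4

The source may hold more compounds than are shown below. What is called first, only, known or untested is meant among the compounds shown, and "the series" means these compounds.

Compound 1 `Cc1c(CC(=O)O)c2ccccc2n1C(=O)c1ccc(OC[C@@H]2CN(C)c3ccccc3O2)c(F)c1`: "not determined" (no result reported) in a functional assay on CHO cells for antagonist activity at prostaglandin D2 receptor (Mus musculus), read by cAMP accumulation and immunoassay, with a stated time of 10 min, in the presence of a further agent that is not named here; on this read-out lower numbers stand for stronger inhibition and higher numbers for weaker inhibition.
Compound 2 `Cc1cc(OC[C@@H]2CN(C)c3ccccc3O2)ccc1C(=O)n1c(C)c(CC(=O)O)c2cc(F)ccc21`: 3.2 nM.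
Compound 3 `Cc1c(CC(=O)O)c2cc(F)ccc2n1C(=O)c1ccc(OC[C@@H]2CN(C)c3ccccc3O2)cc1Cl`: 1.6 nM.

Within the data shown here, of the two numbers available, compound 2 gives the higher one, and the only measured step, a 2.0-fold lower number from compound 2 to compound 3 (0.30 log units; within the scatter), stays within the scatter. Compound 4 `Cc1cc(C(=O)n2c(C)c(CC(=O)O)c3cc(F)ccc32)c(C)cc1OC[C@@H]1CN(C)c2ccccc2O1` differs from compound 2 by methyl in place of hydrogen on an aromatic carbon. Among the measured compounds shown here, no measured step swaps hydrogen for methyl, so the step from compound 2 to compound 3 bears on this change only loosely: there, exchanging one small group on an aromatic carbon moved the number within the scatter. The step from compound 2 to compound 4 is therefore expected to stay within the scatter as well, a 1.3-fold higher number from compound 2 to compound 4 (0.10 log units; within the scatter). Compound 4 is estimated at 4 nM, with a range of 1.3 nM to 13 nM.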

Compound 4, half-maximal inhibitory concentration: 2.8 nM
For compound 4 the middle estimate is 1.4-fold (0.15 log units) above the measured one; the measured number falls inside the stated range.
By their numbers in this assay, from the lowest: compounds 3, 4 and 2 (each within the scatter of the next).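

In this assay, methyl in place of hydrogen on this aromatic carbon, ortho to a large group and para to a methyl group, gives a 1.1-fold lower number from compound 2 to compound 4 (0.06 log units; within the scatter). Among these compounds, the earlier compounds held no swap of hydrogen for methyl, so this is the first direct sign that this carbon takes one added methyl with a step that stays within the scatter. Nothing available here gives a reason for this outcome. From the compounds shown here alone, whether a longer chain such as an ethyl group, or a nitrile, would fare the same on this carbon stays open.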